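The compounds below may be only part of what the source reports. "The series", "measured", "known", "first", "only" and "open" are said of these compounds alone.

Measured compounds:
- compound 1, `COc1ccc(-c2cc(=O)c3c(OC)cc(OC)cc3n2C)cc1`: 68000 nM
- compound 2, `COc1ccc(-c2c(Cl)c(=O)c3c(OC)cc(OC)cc3n2S(=O)(=O)c2ccc(OC)cc2)cc1`: 90000 nM

In an ADME assay on BJ cells (Homo sapiens) for antiproliferative activity, with a stated time of 72 h (a higher number here means that more compound is needed for the effect, a lower number that less compound is needed), compound 1 gives 68000 nM. In this assay compound 2 gives 90000 nM. Compound 2 holds the higher of the two numbers, but its gap to compound 1 lies within the usual scatter of this kind of measurement, so the two values cannot be told apart. Compound 1 and compound 2 differ in more than one place, so their comparison says nothing about any single change.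

Compound 3, `COc1ccc(-c2cc(=O)c3c(OC)cc(OC)cc3n2S(=O)(=O)c2ccc(OC)cc2)cc1`, has not yet been measured in this assay. It is derived from compound 2 by one change: hydrogen in place of chloro on an aromatic carbon. Within the data shown here, no measured pair differs only in this change, so nothing here shows what it does on its own. Among the measured compounds shown here, compound 2 gives 90000 nM, and the one compound that carries hydrogen at that carbon, compound 1, gives 68000 nM, a number that cannot be distinguished from it. The expectation is therefore a step of a 1.1-fold lower number from compound 2 to compound 3 (0.05 log units; within the scatter) that stays within the scatter, in no particular direction. Compound 3 is accordingly estimated at 80000 nM, with a range from 30000 nM to 200000 nM.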

Compound 3, half-maximal effective concentration: > 82700 nM
Compound 3: a limit, no number; the forecaster's own chance of this, stated with the estimate: 25%; middle value at least 1.0-fold (0.01 log units) from the limit.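

Compound 3 ends in a limit of the assay rather than a number: the limit of > 82700 nM in this assay, at which 1 of the 3 values shown sits.

Among these compounds, compounds 2 and 3 form the first pair that differs only by hydrogen in place of chloro on this aromatic carbon, but the limit leaves their step unreadable, so the effect of removing chloro remains unknown. The other pair, compounds 1 and 3, isolates a change at a different place, with (4-methoxyphenyl)sulfonyl in place of methyl on the aromatic nitrogen, and gives an at least 1.2-fold higher number from compound 1 to compound 3 (0.08 log units; that floor lies within the scatter); the real step could be that small or larger, so this pair shows no difference beyond the scatter and cannot exclude one.

The compounds shown carry only chloro or hydrogen at this carbon, so what an amine or a carboxylic acid would do there stays open. On the aromatic nitrogen they carry only methyl or (4-methoxyphenyl)sulfonyl, which leaves open the effect of a longer chain at that place.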